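This account rests on a few compounds, and the source may have more. Where it says the series, first, only, none or still open, it means among the compounds named here.

Measured in a functional assay on MCF7 cells (Homo sapiens) for antiproliferative activity, read by MTT assay, with a stated time of 48 h; a higher number here means a weaker inhibitor, a lower number a stronger inhibitor:
- compound 1 `CN(C)CCNc1cc2c(cn1)cc(NC(=O)c1cc3ccccc3s1)c(=O)n2C`: 12000 nM
- compound 2 `COc1cccc(C(=O)Nc2cc3cnc(NCCN(C)C)cc3n(C)c2=O)c1`: 43300 nM

Of these two compounds, compound 2 stands higher at 43300 nM, which makes it the weaker inhibitor in this assay. Compound 3 `CC(=O)Nc1cc2cnc(NCCN(C)C)cc2n(C)c1=O` has not yet been measured. It keeps the shared core and differs from compound 2 at one place: methyl in place of 3-methoxyphenyl on a carbonyl carbon. This is methyl in place of 3-methoxyphenyl on a carbonyl carbon.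

Among the compounds with values here, only one measured step bears on this change: a 3.6-fold higher number from compound 1 to compound 2 (0.56 log units; beyond the scatter). It was made on a carbonyl carbon too, and it shows that the group there can move the number modestly, beyond the scatter. Within the data shown here, both measured compounds carry a ring at this place, however, and no measured compound has a methyl there, so the new change goes outside what has been tested. With that caution, a modest further rise is expected rather than a large one, and the direction is uncertain. The expected move is a 1.6-fold higher number from compound 2 to compound 3 (0.21 log units; within the scatter). For compound 3 the estimated value is 70000 nM, with an expected range of 25000 nM to 200000 nM.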

Compound 3, half-maximal inhibitory concentration: > 100000 nM
Compound 3: a limit, no number; the forecaster's own chance of this, stated with the estimate: 35%; middle value at least 1.4-fold (0.15 log units) away from the limit.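

In this assay compound 3 gives > 100000 nM, which is a limit of the assay and not a number. From the compounds shown here alone, replacing the ring on the carbonyl carbon with methyl gives an at least 2.3-fold higher number from compound 2 to compound 3 (0.36 log units; beyond the scatter), and the same comparison with the fused ring group gives an at least 8.3-fold higher number from compound 1 to compound 3 (0.92 log units; beyond the scatter), so both steps lie beyond the scatter, though their true sizes stay unknown. Within the data shown here, the earlier pair showed only that one ring could be exchanged for another at this place with a modest shift, whereas these steps show that among the three compounds, the two that carry a ring on the carbonyl carbon give the lower numbers.

The compounds shown leave open whether the aromatic ring itself matters or only the number of atoms carried at this place, a question that a longer chain such as hexyl or a saturated ring such as cyclohexyl on the carbonyl carbon would address. They also leave open how much the methoxy group contributes to the number of compound 2, which an unsubstituted phenyl at the same place would help to settle.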